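A few compounds are considered here, and "the series" means these few. Any claim that something is new, unique, unknown or untested is made for them only; others in the source may bear on it.

Measured compounds:
Compound 1 `O=C(/C=C\c1ccccc1)N1N=C(c2ccncc2)OC1c1c[nH]c2ccccc12`: in an ADME assay on A549 cells (Homo sapiens) for cytotoxicity, read by MTT assay, with a stated time of 48 h (on this read-out lower numbers stand for stronger inhibition of growth and higher numbers for weaker inhibition of growth), compound 1 gives > 30 ug/mL, a limit of the assay.
Compound 2 `O=C(/C=C\c1ccc(O)cc1)N1N=C(c2ccncc2)OC1c1c[nH]c2ccccc12`: in this assay compound 2 gives > 30 ug/mL, again a limit.
Compound 3 `O=C(/C=C\c1cccc(Cl)c1)N1N=C(c2ccncc2)OC1c1c[nH]c2ccccc12`: in this assay compound 3 gives > 30 ug/mL, also a limit.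

Compound 2 therefore stands at the limit of this assay, as do both of its neighbours; the limit of > 30 ug/mL in this assay, at which 3 of the 3 values shown sit, summarises this. The change to compound 4 `O=C(/C=C/c1c(Cl)cccc1Cl)N1N=C(c2ccncc2)OC1c1c[nH]c2ccccc12` is 2-(2,6-dichlorophenyl)ethenyl in place of 2-(4-hydroxyphenyl)ethenyl on a carbonyl carbon. The steps that touch it are a step that the two limits leave unreadable from compound 1 to compound 2, a step that the two limits leave unreadable from compound 1 to compound 3 and a step that the two limits leave unreadable from compound 2 to compound 3; none of them is readable, so no size or direction of step in this assay can be drawn from them. Compound 4 is therefore expected to sit at the same limit, with an estimated 40 ug/mL, range 20 ug/mL to 100 ug/mL. The step that this estimate implies for compound 4 is a step that the limit leaves unreadable from compound 2 to compound 4, which is expected to stay within the scatter.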

Compound 4, concentration for 50% growth inhibition: > 30 ug/mL
Compound 4 gave a limit, no number; the forecaster's own chance of this, stated with the estimate: 75%; the middle value does not contradict the limit.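

Compound 4 gives > 30 ug/mL in this assay, again a limit, so its steps from compound 1, compound 2 and compound 3 cannot be read. The compounds shown leave open whether any change on the carbonyl carbon would give a readable value: the limit of > 30 ug/mL in this assay, at which 4 of the 4 values shown sit.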